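This account rests on a few compounds, and the source may have more. Where it says the series, first, only, none or still open, it means among the compounds named here.

Compound 1, with the structure `N[C@H]1CC[C@H](Nc2c(C(=O)NCc3ccc(F)cc3)nc(Br)c3cccnc23)CC1`, is the anchor of this small series. Among the measured compounds shown here, in a functional assay on MCF7 cells (Homo sapiens) for cytotoxicity, read by MTT assay, with a stated time of 72 h (a lower number here means a stronger inhibitor, a higher number a weaker inhibitor), compound 1 gives 2000 nM, and this is the only number on record: compound 2, with the structure `O=C(NCc1ccc(F)cc1)c1nc(Br)c2cccnc2c1NCCO`, is recorded in this assay as "not determined" (no result reported), so compound 1 stands alone as the single measured point rather than as the strongest or weakest of anything.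

Compound 3, with the structure `N[C@H]1CC[C@H](Nc2c(C(=O)NCc3ccccn3)nc(Br)c3cccnc23)CC1`, keeps the shared core of compound 1 and changes only the amide substituent: pyridin-2-yl in place of 4-fluorophenyl on a saturated chain carbon bound to an amide-type nitrogen. No comparison between two measured compounds is available, so the size of this kind of change in this assay cannot be read from the data themselves.

On that basis compound 3 is expected to sit close to compound 1, with a step from compound 1 to compound 3 estimated at a 1.5-fold higher number from compound 1 to compound 3 (0.18 log units; within the scatter), not clearly beyond the usual scatter. Compound 3 is therefore estimated to give 3000 nM, within a range of 1000 nM to 10000 nM.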

Compound 3, half-maximal inhibitory concentration: 15000 nM
Beside the measured number, compound 3's estimate is 5.0-fold (0.70 log units) below it; measured number outside the range, above it.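

Among the compounds shown here, the step from the anchor gives the first comparison: in this assay, pyridin-2-yl in place of 4-fluorophenyl on a saturated chain carbon bound to an amide-type nitrogen gives a 7.5-fold higher number from compound 1 to compound 3 (0.88 log units; beyond the scatter). This shows that the amide substituent is not a silent position in this assay, since exchanging one six-membered aromatic ring for another moves the result beyond the scatter, towards a weaker inhibitor. No measurement at hand accounts for this step.

The change removes the fluorine and adds a ring nitrogen in a single move, so this one pair cannot separate the two. A plain phenyl group, or pyridin-3-yl or pyridin-4-yl at the same place, would show whether the step follows the loss of fluorine or the ring nitrogen and its location.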